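Cyano to Chloro: Expected Cytotoxicity of Compound 4

The source may hold more compounds than are shown below. What is called first, only, known or untested is meant among the compounds shown, and "the series" means these compounds.

Three measured compounds share one core. Compound 1 `COc1cc(CC(O)c2ccc(-c3ccc(Br)cc3)cc2)c([N+](=O)[O-])cc1OC` gives 4300 nM in an ADME assay on HeLa Rh cells (Homo sapiens) for cytotoxicity, read by microscopy (on this read-out lower numbers stand for higher toxicity in this test and higher numbers for lower toxicity in this test), compound 2 `COc1cc(CC(O)c2ccc(-c3cccc([N+](=O)[O-])c3)cc2)c([N+](=O)[O-])cc1OC` gives 5500 nM, and compound 3 `COc1cc(CC(O)c2cccc(-c3ccc(C#N)cc3)c2)c([N+](=O)[O-])cc1OC` gives 9300 nM, the top of the three numbers, separated from compound 2 by a gap within the scatter and from compound 1 by one beyond it. For the measured compounds named here, the only single-point step measured is a 1.3-fold higher number from compound 1 to compound 2 (0.11 log units; within the scatter). Compound 4 `COc1cc(CC(O)c2cccc(-c3ccc(Cl)cc3)c2)c([N+](=O)[O-])cc1OC` differs from compound 3 by chloro in place of cyano on an aromatic carbon. Going by the values given here, no measured step exchanges cyano for chloro, so the expectation rests on the small size of the one aryl exchange seen and on compound 1, whose 4300 nM carries a halogen on the outer ring. A step of a 1.4-fold lower number from compound 3 to compound 4 (0.16 log units; within the scatter) is therefore expected. Compound 4 is estimated at 6500 nM, between 3000 nM and 14000 nM.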

Compound 4, half-maximal cytotoxic concentration: 5000 nM
Compound 4: the middle estimate sits 1.3-fold (0.11 log units) above what was measured; the range from low to high includes it.
By their numbers in this assay, from the lowest: compounds 1, 4, 2 and 3 (each within the scatter of the next, the first and the last beyond it).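

For the compounds shown here, on an aromatic carbon para to a large group, chloro in place of cyano gives a 1.9-fold lower number from compound 3 to compound 4 (0.27 log units; within the scatter) in this assay and is the first direct reading of this exchange. The nitrile and the chloro group, which differ in heavy atoms and hydrogen-bond acceptors, are therefore not told apart at this position by this read-out. No available evidence bears on why the exchange reads this way. Open, as far as these compounds go, is how an amine or a carboxylic acid would read at this position. Also open, from the compounds shown here alone, is whether the same exchange would read alike elsewhere on the shared core.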